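The compounds below may be only part of what the source reports. "The series", "measured", "known", "first", "only" and "open" are said of these compounds alone.

The compounds here share one core and differ in the groups hung on it. In a functional assay on HeLa cells (Homo sapiens) for inhibition, read by cell counting, with a stated time of 4 days (on this read-out lower numbers stand for stronger inhibition and higher numbers for weaker inhibition), compound 1, `Nc1cccc(-c2cn3nc(-c4cccs4)sc3n2)c1`, does not reach a number at all: its result, > 250000 nM, is a limit of the assay. The value of compound 1 is the limit of > 250000 nM in this assay, at which 1 of the 3 values shown sits. Compound 3, `Nc1cccc(-c2cn3nc(CCc4ccccc4)sc3n2)c1`, gives 242000 nM in this assay. Compound 2, `C=C(Br)C(=O)Nc1cccc(-c2cn3nc(-c4ccc(CC)cc4)sc3n2)c1`, gives 3200 nM in this assay, which is the lowest of the two numbers shown, and the number of compound 3 lies higher by a gap beyond the usual scatter.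

Compound 4, `C=C(Br)C(=O)Nc1cccc(-c2cn3nc(-c4cccc(OC)c4)sc3n2)c1`, has not yet been measured. It keeps everything in compound 2 except one group: 3-methoxyphenyl in place of 4-ethylphenyl on an aromatic carbon. No measured pair among these compounds shows what such an exchange does on its own, so the expectation rests on the closeness of the two groups in size and shape. Only a small shift, one that should stay within the scatter of repeated measurements, is expected: a 1.3-fold higher number from compound 2 to compound 4 (0.10 log units; within the scatter). Compound 4 is therefore estimated to give 4000 nM, with a likely range from 1200 nM to 14000 nM.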

Compound 4, half-maximal inhibitory concentration: 1100 nM
For compound 4 the middle estimate is 3.6-fold (0.56 log units) above the measured one, outside the stated range (below it).
By their numbers in this assay, from the lowest: compound 4; then compound 2; then compound 3. At a limit, above all of these: compound 1.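

Within the data shown here, this is the first direct reading of what an exchange at this position does on its own: with the rest of the molecule unchanged, putting 3-methoxyphenyl in place of 4-ethylphenyl gives a 2.9-fold lower number from compound 2 to compound 4 (0.46 log units; beyond the scatter) in this assay. The aromatic carbon next to the ring nitrogen and next to the ring sulfur is therefore not indifferent to which substituted phenyl it carries, even though both groups count the same number of heavy atoms. The entering group does hold one hydrogen-bond acceptor where the leaving group holds none, but nothing shown here connects that difference, or any other, to the size or direction of this step.

The exchange alters two things at once, the kind of substituent and its place on the phenyl ring, and the compounds shown do not pull these apart, which a pair with 4-methoxyphenyl or 3-ethylphenyl at this position could do. Also open, as far as these compounds go, is how this position responds to quite different groups, such as 3-aminophenyl, 3-carboxyphenyl or a phenyl ring bearing a longer chain than ethyl.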